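From a phenylpropyl chain to a methoxyphenyl sulfonamide

The compounds below may be only part of what the source reports. "The series", "measured", "known", "first", "only" and "open" are said of these compounds alone.

- compound 1 `CS(=O)(=O)N[C@H]1C2CC[C@H](C2)[C@@H]1C/C=C\CCCC(=O)O` gives 640000 nM
- compound 2 `O=C(O)CCC/C=C\C[C@H]1[C@@H]2CCC(C2)[C@@H]1NS(=O)(=O)c1cccc2ccccc12` gives 1100 nM
- compound 3 `O=C(O)CCC/C=C\C[C@H]1[C@@H]2CCC(C2)[C@@H]1NS(=O)(=O)CCCc1ccccc1` gives 14000 nM

In a functional assay (plasma) for inhibition, with Oryctolagus cuniculus as the target (on this read-out lower numbers stand for stronger inhibition and higher numbers for weaker inhibition), compound 3 gives 14000 nM and so holds the second highest of the three numbers. Compound 4 `COc1ccc(S(=O)(=O)N[C@H]2C3CC[C@H](C3)[C@@H]2C/C=C\CCCC(=O)O)cc1` differs from compound 3 in one place (4-methoxyphenyl in place of 3-phenylpropyl on a sulfonyl sulfur) and has 4-methoxyphenyl in place of 3-phenylpropyl on a sulfonyl sulfur.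

The group at this place has already moved the number a long way, as the data show a 580-fold lower number from compound 1 to compound 2 (2.76 log units; beyond the scatter) and a 46-fold lower number from compound 1 to compound 3 (1.66 log units; beyond the scatter) in this assay for the two changes away from methyl. Compound 2 carries naphthalen-1-yl there, an aromatic group as in compound 4, and the data show a 13-fold higher number from compound 2 to compound 3 (1.10 log units; beyond the scatter) when that group gives way to 3-phenylpropyl. Among the measured compounds shown here, no measured compound carries 4-methoxyphenyl, so a large step to a lower number is expected, though perhaps somewhat smaller than that one. The estimate means a 5.6-fold lower number from compound 3 to compound 4 (0.75 log units; beyond the scatter) in this assay for this change. Compound 4 is expected at 2500 nM with an estimated range from 500 nM to 11000 nM in this assay once it is measured.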

Compound 4, half-maximal inhibitory concentration: 1700 nM
For compound 4 the middle estimate is 1.5-fold (0.17 log units) above the measured one, within the range that was stated.
By their numbers in this assay, from the lowest: compounds 2 and 4 (each within the scatter of the next); then compound 3; then compound 1.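

In this assay, replacing the 3-phenylpropyl chain on the sulfonyl sulfur with 4-methoxyphenyl gives an 8.2-fold lower number from compound 3 to compound 4 (0.92 log units; beyond the scatter) and so shows that a single substituted benzene ring can do better than that chain at this position. Swapping naphthalen-1-yl for 4-methoxyphenyl gives a 1.5-fold higher number from compound 2 to compound 4 (0.19 log units; within the scatter) and leaves the two groups indistinguishable here, so the second ring of naphthalen-1-yl is not needed to keep this level, and the change from methyl still amounts to a 380-fold lower number from compound 1 to compound 4 (2.58 log units; beyond the scatter) in this series. Nothing measured here explains why these groups differ. As far as these compounds go, what the methoxy group adds by itself remains open, and a plain phenyl on the sulfonyl sulfur would address that. Also open, from the compounds shown here alone, is whether an amine or a carboxylic acid in its place would move the number further.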